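Solubility of an Amine-Linked Core: an Ether Gives Way to a Benzyl Group

A few compounds are considered here, and "the series" means these few. Any claim that something is new, unique, unknown or untested is made for them only; others in the source may bear on it.

Of the compounds shown here, three sharing one core have been measured in a physicochemical assay for solubility, with a stated time of 18 h, at pH 7.4; a lower number here means a less soluble compound, a higher number a more soluble compound. Compound 1, `COc1ccccc1Oc1ccc2c(NCCCNCc3ccco3)ccnc2c1`, gives 14500 nM. Compound 2, `COc1cccc(CNCCCNc2ccnc3cc(Oc4ccc(Cl)cc4)ccc23)c1O`, gives 14500 nM, the same number at the digits printed, so the two stand level, together the lowest of the three. Compound 3, `COc1ccc(F)cc1CNCCCNc1ccnc2cc(-c3ccccc3)ccc12`, gives 32000 nM, a higher number than compound 1, and that gap lies beyond the usual scatter. For the measured compounds named here, compound 3 differs from compound 1 in more than one place, so its two values show only that a compound of this series can reach a higher reading.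

The next compound, compound 4, is `Fc1ccc(Cc2ccc3c(NCCCNCc4ccco4)ccnc3c2)cc1`. It is derived from compound 1 by a single change: 4-fluorobenzyl in place of 2-methoxyphenoxy on an aromatic carbon. The 2-methoxyphenoxy group that leaves carries two hydrogen-bond acceptors; the 4-fluorobenzyl group that enters carries none, and both are without charge.

Going by the values given here, no measured pair in this set isolates such a change, so the direction has to be taken as open. The expectation for compound 4 in this assay is a step of a 1.2-fold lower number from compound 1 to compound 4 (0.08 log units; within the scatter), which is to say none clearly beyond the scatter. On that basis compound 4 is estimated at 12000 nM, with a range from 4000 nM to 35000 nM.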

Compound 4, solubility: 4200 nM
Compound 4: the middle estimate sits 2.9-fold (0.46 log units) above what was measured, and the stated range covers the measured number.
By their numbers in this assay, from the lowest: compound 4; then compounds 1 and 2 (each within the scatter of the next); then compound 3.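

In this assay, for the compounds shown here, putting 4-fluorobenzyl in place of 2-methoxyphenoxy on this aromatic carbon gives a 3.5-fold lower number from compound 1 to compound 4 (0.54 log units; beyond the scatter), the first step in the set that isolates a change in one place. It shows that the reading is not indifferent to what this position carries: with the rest of compound 1 held constant, this exchange alone moves the number beyond the scatter. The 2-methoxyphenoxy group carries two hydrogen-bond acceptors and the 4-fluorobenzyl group none, but nothing measured here explains the step or ties it to that difference.

This single pair changes the linking atom and both ring substituents at once, so it cannot say which of them matters; a plain phenoxy or an unsubstituted benzyl group at this carbon would begin to separate them. It also leaves open how other groups at this position, such as a morpholine or a carboxylic acid, would read, and whether the same exchange would give a similar step with a substituted benzylamine in place of the furan-bearing side chain.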